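Shortening the side chain of compound 2

A few compounds are considered here, and "the series" means these few. Any claim that something is new, unique, unknown or untested is made for them only; others in the source may bear on it.

Compound 1 `COCCCCCCCCCCCCCCC/C=C1/CC(CO)(COC(=O)C(C)(C)C)OC1=O` gives 2.13 ug/mL
Compound 2 `COCCCCCCCCCCCCCCC/C=C1\CC(CO)(COC(=O)C(C)(C)C)OC1=O` gives 1.75 ug/mL

Both values come from a functional assay on SK-MEL-5 cells (Homo sapiens) for antiproliferative activity (a lower number here means a stronger inhibitor of growth, a higher number a weaker inhibitor of growth), and the two compounds differ only in how one double bond is drawn. The measured change is a 1.2-fold lower number from compound 1 to compound 2 (0.09 log units; within the scatter), so compound 2 stands level with compound 1 and neither can be ranked above the other.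

Compound 3 `COCCCCCCCCCCC/C=C1\CC(CO)(COC(=O)C(C)(C)C)OC1=O` keeps the double bond as drawn in compound 2 but has a shorter chain: methoxy in place of 4-methoxybutyl on a saturated chain carbon, ten or more bonds along the chain from a double-bonded chain carbon. In words, this is methoxy in place of 4-methoxybutyl on a saturated chain carbon, ten or more bonds along the chain from a double-bonded chain carbon.

For the measured compounds named here, the single measured step concerns the double bond, not the chain length, so it bears on this change only weakly. Going by the values given here, no measured compound has a shorter chain, and the direction of any shift in this assay cannot be read from these data. The starting point is therefore compound 2 at 1.75 ug/mL, and no step beyond the scatter is expected, though with wide uncertainty. The expected change is a 1.3-fold higher number from compound 2 to compound 3 (0.10 log units; within the scatter), a rough estimate. Compound 3 is expected at 2.2 ug/mL, with an estimated range from 0.8 ug/mL to 7 ug/mL.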

Compound 3, concentration for 50% growth inhibition: 2.81 ug/mL
Compound 3: the middle estimate sits 1.3-fold (0.11 log units) below what was measured; the range from low to high includes it.
By their numbers in this assay, from the lowest: compounds 2, 1 and 3 (each within the scatter of the next).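

Up to this point, the only measured comparison concerned how the double bond is drawn, so compound 3 gives the first reading on the side chain itself. In this assay, methoxy in place of 4-methoxybutyl on a saturated chain carbon gives a 1.6-fold higher number from compound 2 to compound 3 (0.21 log units; within the scatter), so at this position the chain can go from the longer group to the shorter one without a change that stands clear of repeated measurements. For the compounds shown here, nothing available explains this small step, and the one piece of supporting information concerns only the double bond of compounds 1 and 2, not the chain length.

A single step cannot show whether a still shorter chain, a longer chain, or a carboxylic acid or an amine in place of the methoxy would give a number beyond the scatter. It also leaves open whether the same chain change would give a similar step with the double bond drawn as in compound 1.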